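Nitrooxyacetyl hydrazides: removing the para chloro on compound 3

A few compounds are considered here, and "the series" means these few. Any claim that something is new, unique, unknown or untested is made for them only; others in the source may bear on it.

Measured so far in a functional assay on the whole organism (strain Wistar) for inhibition, with Rattus norvegicus as the target, read by paw edema, with stated times of 2 h and 1 h, at a dose of 6 mg/kg by the oral route; a lower number here means less inhibition, a higher number more inhibition at the dose given (going by the name of the read-out):
- compound 1, `O=C(CO[N+](=O)[O-])NNC(=O)c1ccc(-n2[nH]c(=O)cc2-c2ccc([N+](=O)[O-])cc2)cc1`: 27.1%
- compound 2, `COc1ccccc1-c1cc(=O)[nH]n1-c1ccc(C(=O)NNC(=O)CO[N+](=O)[O-])cc1`: 55.7%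
- compound 3, `O=C(CO[N+](=O)[O-])NNC(=O)c1ccc(-n2[nH]c(=O)cc2-c2ccc(Cl)cc2)cc1`: 11.5%

Compound 3 stands lowest of the three in this assay; compound 1 is its nearest neighbour and compound 2 the furthest, both steps being beyond the scatter: a number 15.6 percentage points lower from compound 1 to compound 3 (beyond the scatter) and a number 44.2 percentage points lower from compound 2 to compound 3 (beyond the scatter). Compound 1 and compound 2 are separated by a number 28.6 percentage points higher from compound 1 to compound 2 (beyond the scatter).

Compound 4, `O=C(CO[N+](=O)[O-])NNC(=O)c1ccc(-n2[nH]c(=O)cc2-c2ccccc2)cc1`, differs from compound 3 by hydrogen in place of chloro on an aromatic carbon. Going by the values given here, no measured step removes a group from this ring to leave hydrogen; the nearest is the exchange of nitro for chloro at the same place, which read a number 15.6 percentage points lower from compound 1 to compound 3 (beyond the scatter). Changes at this ring have moved the read-out in either direction by modest to large amounts, so a modest step in this assay is expected, and with chloro giving the lowest number so far the direction is taken as upward, though weakly.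

Compound 4 is therefore estimated at 22%, between 8% and 38%, which means an expected step of a number 10.5 percentage points higher from compound 3 to compound 4 (beyond the scatter).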

Compound 4, a percentage reported as inhibition, in the whole organism at one dose (the size of the read-out at that dose, not a potency): 16.1%
Beside the measured number, compound 4's estimate is 5.9 percentage points above it; measured number inside the range.
By their numbers in this assay, from the lowest: compounds 3 and 4 (each within the scatter of the next); then compound 1; then compound 2.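

Working from this assay, the step of a number 4.6 percentage points higher from compound 3 to compound 4 (within the scatter) shows that hydrogen and chloro cannot be told apart at this place, so compound 3's low reading gives no sign that chloro itself lowers the inhibition. Phenyl now gives an unsubstituted reference for this ring, and both other compounds stand clear of it: a number 11 percentage points lower from compound 1 to compound 4 (beyond the scatter) is modest and a number 39.6 percentage points lower from compound 2 to compound 4 (beyond the scatter) is large, so the ring substituents in compound 1 and compound 2 are linked to higher numbers, while chloro in compound 3 is not. Nothing available bears on the cause of these steps.

Compound 2 alone carries the 2-methoxyphenyl group, so the effect of methoxy cannot be separated from that of its place on the ring. On these data alone, how an amine or a hydroxyl group at this ring would read remains open.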